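Carbamate in Place of Fluorophenyl on the Ring Nitrogen

The source may report more compounds than this note shows. Statements on the series, on what has been measured and on what is new or still open speak of the compounds shown alone.

Compound 1 `CCCCCCCCn1cc(/C=C/C(=O)c2ccc(NC(=O)CN3CCN(c4ccccc4F)CC3)cc2)nn1` shares its core with two other measured compounds. Within the data shown here, in a functional assay on MCF7 cells (Homo sapiens) for inhibition, read by MTT assay (on this read-out lower numbers stand for stronger inhibition and higher numbers for weaker inhibition), compound 1 gives 68600 nM, the highest of the three numbers so far, though compound 2 `CCCCCCCCCCn1cc(/C=C/C(=O)c2ccc(NC(=O)CN3CCC(Cc4ccccc4)CC3)cc2)nn1` with 55200 nM and compound 3 `CCCCCCCCCCn1cc(/C=C/C(=O)c2ccc(N)cc2)nn1` with 52600 nM both lie within the scatter of it, so no order among the three can be claimed. Compound 4 `CCCCCCCCn1cc(/C=C/C(=O)c2ccc(NC(=O)CN3CCN(C(=O)OC(C)(C)C)CC3)cc2)nn1` differs from compound 1 by tert-butoxycarbonyl in place of 2-fluorophenyl on an amine nitrogen in a ring. Among the measured compounds shown here, no measured pair shows this change, and the three values so far sit close together whatever the core carries at that end. The expected change is a 1.1-fold lower number from compound 1 to compound 4 (0.06 log units; within the scatter), none beyond the scatter. Compound 4 is estimated at 60000 nM, with a range from 25000 nM to 150000 nM.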

Compound 4, half-maximal inhibitory concentration: 98400 nM
Beside the measured number, compound 4's estimate is 1.6-fold (0.21 log units) below it; low and high end bracket the measured number.
By their numbers in this assay, from the lowest: compounds 3, 2, 1 and 4 (each within the scatter of the next).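

Among these compounds, the first measured step at this position shows that, in this assay, tert-butoxycarbonyl in place of 2-fluorophenyl gives a 1.4-fold higher number from compound 1 to compound 4 (0.16 log units; within the scatter). The read-out therefore does not separate these two groups on the amine nitrogen in the ring, although the entering group has no ring and carries 2 hydrogen-bond acceptors where the leaving group carries 0. Nothing measured here speaks to what lies behind this result.

The compounds shown leave open whether a free amine or a carboxylic acid on this nitrogen would move the number beyond the scatter. They also leave open whether this change would read the same with a longer chain on the shared core.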